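Swapping Methylsulfanyl for Methoxyphenyl: Expecting Compound 4

This account rests on a few compounds, and the source may have more. Where it says the series, first, only, none or still open, it means among the compounds named here.

Compound 1 `CCOC(=O)c1cnc(CC)nc1NN1C(=O)C=C(C)C1=O` gives 10000 nM in a functional assay on Jurkat cells for inhibition of nuclear factor NF-kappa-B complex (Homo sapiens); a lower number here means a stronger inhibitor, a higher number a weaker inhibitor.
Compound 2 `CCOC(=O)c1cnc(SC)nc1NN1C(=O)C=C(C)C1=O` gives 200 nM in this assay.
Compound 3 `CCOC(=O)c1cnc(-c2cc(Cl)nc(Cl)c2)nc1NN1C(=O)C=C(C)C1=O` gives 2000 nM in this assay.

Among the three measured compounds, compound 2 has the lowest number: compound 3 sits a 10-fold higher number from compound 2 to compound 3 (1.00 log units; beyond the scatter), and compound 1 is further away, at a 50-fold lower number from compound 1 to compound 2 (1.70 log units; beyond the scatter) read in the other direction.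

Compound 4 `CCOC(=O)c1cnc(-c2ccc(OC)cc2)nc1NN1C(=O)C=C(C)C1=O` has not yet been measured. It differs from compound 2 in one place: 4-methoxyphenyl in place of methylsulfanyl on an aromatic carbon. The shared core and the ethoxycarbonyl group are unchanged.

Going by the values given here, the one measured step that resembles this change most closely is the one in which an aromatic ring likewise replaces the methylsulfanyl group: from compound 2 to compound 3 the number rose, a 10-fold higher number from compound 2 to compound 3 (1.00 log units; beyond the scatter). The step from the ethyl compound to that same ring, a 5.0-fold lower number from compound 1 to compound 3 (0.70 log units; beyond the scatter), shows the ring well ahead of ethyl but behind methylsulfanyl. With only one aromatic replacement on record, and a different ring here, the expectation carries real uncertainty, but the direction it suggests is an increase in this assay, probably of modest size.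

Compound 4 is therefore expected to give about 2000 nM, within a range of 500 nM to 8000 nM. This estimate corresponds to an expected step of a 10-fold higher number from compound 2 to compound 4 (1.00 log units; beyond the scatter).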

Compound 4, half-maximal inhibitory concentration: 900 nM
The estimate for compound 4 lay 2.2-fold (0.35 log units) above the measured number; low and high end bracket the measured number.
By their numbers in this assay, from the lowest: compound 2; then compound 4; then compound 3; then compound 1.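

In this assay, a second aromatic ring on this carbon between two ring nitrogen atoms again falls short of methylsulfanyl (a 4.5-fold higher number from compound 2 to compound 4 (0.65 log units; beyond the scatter)), and this time the ring is a six-membered aromatic ring of carbon only, so the earlier shortfall was not confined to 2,6-dichloropyridin-4-yl. The two rings are also not interchangeable (a 2.2-fold lower number from compound 3 to compound 4 (0.35 log units; beyond the scatter)), which shows that the identity of the ring matters here and not merely the presence of one. The 4-methoxyphenyl group also stands well ahead of ethyl (an 11-fold lower number from compound 1 to compound 4 (1.05 log units; beyond the scatter)), so the four groups do not split simply into rings and non-rings: methylsulfanyl, which has no ring, gives the lowest number, and ethyl, which also has no ring, gives the highest.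

Nothing in the available data explains this order. Open questions are whether the methoxy group itself contributes, which an unsubstituted phenyl ring would test, and whether a longer sulfur chain such as ethylsulfanyl, or an amine on the same carbon, could match or improve on methylsulfanyl.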